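Alkoxy benzamides at the alpha4/beta2 receptor: methyl to bromo

The source may hold more compounds than are shown below. What is called first, only, known or untested is meant among the compounds shown, and "the series" means these compounds.

Measured compounds:
compound 1, `C=C(C)COc1ccc(C(=O)Nc2cccc(C)n2)cc1`, 19600 nM;
compound 2, `C#CCOc1ccc(C(=O)Nc2cccc(C)n2)cc1`, 19400 nM;
compound 3, `CCCOc1ccc(C(=O)Nc2cccc(C)n2)cc1`, 7500 nM.

Three compounds share one core and differ only in the chain on the ether oxygen. In an in vitro assay on HEK-tsA201 cells for antagonist activity at Neuronal acetylcholine receptor; alpha4/beta2 (Homo sapiens), read by fluorescence and calcium flux (on this read-out lower numbers stand for stronger inhibition and higher numbers for weaker inhibition), compound 3 gives the lowest number of the three. The steps of a 2.6-fold lower number from compound 1 to compound 3 (0.42 log units; beyond the scatter) and a 2.6-fold lower number from compound 2 to compound 3 (0.41 log units; beyond the scatter) are both beyond the scatter, while a 1.0-fold lower number from compound 1 to compound 2 (0.00 log units; within the scatter) is within it.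

Compound 4, `CCCOc1ccc(C(=O)Nc2cccc(Br)n2)cc1`, keeps the propoxy chain of compound 3 and changes the other end: bromo in place of methyl on an aromatic carbon. Among the measured compounds shown here, none of the measured steps touches that ring position; all of them lie on the chain carbon bound to the ether oxygen, so they give no direct guidance on the size or direction of this change. The expectation therefore rests on compound 3 alone, whose value of 7500 nM serves as the anchor. Compound 4 is expected to show a step of no change at the digits printed from compound 3 to compound 4 (within the scatter), which means no change beyond the scatter, with a wide range to reflect the absence of a comparable step. Compound 4 is thus estimated at 7500 nM, between 2000 nM and 30000 nM.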

Compound 4, half-maximal inhibitory concentration: 80700 nM
The estimate for compound 4 lay 11-fold (1.03 log units) below the measured number; the whole stated range lies below it.
By their numbers in this assay, from the lowest: compound 3; then compounds 2 and 1 (each within the scatter of the next); then compound 4.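

Bromo in place of methyl on this aromatic carbon, next to the ring nitrogen, gives an 11-fold higher number from compound 3 to compound 4 (1.03 log units; beyond the scatter) in this assay and so moves the number further than any of the chain changes among compound 1, compound 2 and compound 3 did. This shows that the ring position affects inhibition on this read-out, and the change is large even though the counts of heavy atoms, hydrogen-bond donors and hydrogen-bond acceptors are the same for the two groups. Nothing available here bears on why this step is so large.

The compounds shown leave open how hydrogen, chloro, methoxy or an amine would read at this position. They also leave open whether the step would keep its size with the chains of compound 1 and compound 2.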